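Acetylated sugar triazoles: furan in place of dimethoxyphenyl

The compounds below may be only part of what the source reports. "The series", "measured", "known", "first", "only" and "open" are said of these compounds alone.

The series carries a peracetylated sugar on a triazole whose methylene bears the variable aromatic part. In an ADME assay on NIH3T3 cells (Homo sapiens) for cytotoxicity, read by sulforhodamine B assay, with a stated time of 48 h (on this read-out lower numbers stand for stronger inhibition and higher numbers for weaker inhibition), compound 1 `COc1ccc2c(c1)c(/C=N/O)cn2Cc1cn([C@@H]2O[C@H](COC(C)=O)[C@@H](OC(C)=O)[C@H](OC(C)=O)[C@H]2OC(C)=O)nn1` gives 26200 nM. Compound 2 `CC(=O)OC[C@H]1O[C@@H](n2cc(CN3C(=O)/C(=C/c4ccc(C)cc4)c4ccccc43)nn2)[C@H](OC(C)=O)[C@@H](OC(C)=O)[C@@H]1OC(C)=O` gives 73300 nM in this assay. Compound 3 `COc1ccc(/C=C2\C(=O)N(Cc3cn([C@@H]4O[C@H](COC(C)=O)[C@@H](OC(C)=O)[C@H](OC(C)=O)[C@H]4OC(C)=O)nn3)c3ccccc32)cc1OC` reaches only the limit of this assay and gives > 100000 nM, which is a limit and not a number. On the numbers shown, compound 3 therefore stands at the weak end of the set, at the limit of > 100000 nM in this assay, at which 1 of the 3 values shown sits, while compound 1 and compound 2 both return numbers inside the measured range. Within the data shown here, no pair of measured compounds differs in a single place, so no measured step exists against which the next change can be set.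

Compound 4 `CC(=O)OC[C@H]1O[C@@H](n2cc(CN3C(=O)/C(=C\c4ccco4)c4ccccc43)nn2)[C@H](OC(C)=O)[C@@H](OC(C)=O)[C@@H]1OC(C)=O` differs from compound 3 by furan-2-yl in place of 3,4-dimethoxyphenyl on a double-bonded chain carbon bound to a double-bonded ring carbon. Compound 2, which also carries a single aromatic group at that position, gives a number rather than a limit, so weak but measurable inhibition is plausible for compound 4. The step in this assay is expected to be small, toward somewhat stronger inhibition at most, and possibly none beyond the scatter. Compound 4 is expected to give 90000 nM in this assay, within 40000 nM to 200000 nM. The expected step is an at least 1.1-fold lower number from compound 3 to compound 4 (0.04 log units; that floor lies within the scatter), with a real chance that only a limit is returned.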

Compound 4, half-maximal inhibitory concentration: 13300 nM
The estimate for compound 4 lay 6.8-fold (0.83 log units) above the measured number; the measured number lies below the stated range.
By their numbers in this assay, from the lowest: compounds 4 and 1 (each within the scatter of the next); then compound 2. At a limit, above all of these: compound 3.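

In this assay, furan-2-yl in place of 3,4-dimethoxyphenyl on a double-bonded chain carbon bound to a double-bonded ring carbon gives an at least 7.5-fold lower number from compound 3 to compound 4 (0.87 log units; beyond the scatter), the only single-place step shown in the series and one that lies beyond the scatter. This position therefore responds to the aromatic group it carries: a change there alone, with the acetylated sugar, the triazole and the rest of the shared core held constant, moves the read-out from a limit into the measured range. Compound 3 stands at a limit and not at a number, so the step is only a floor on the change: the limit of > 100000 nM in this assay, at which 1 of the 4 values shown sits.

A single step cannot separate the exchange of a six-membered carbon ring for a five-membered ring with one hetero atom from the loss of the two methoxy groups, or from the drop in heavy atoms that comes with it. From the compounds shown here alone, whether an unsubstituted phenyl, a 4-methoxyphenyl, a thiophen-2-yl or a pyridin-3-yl at the same position would follow furan-2-yl or 3,4-dimethoxyphenyl remains open, and so does the size of the step.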